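Adding a Fluoro Group to Compound 2

The source may hold more compounds than are shown below. What is called first, only, known or untested is meant among the compounds shown, and "the series" means these compounds.

In an ADME assay on the whole organism (Rattus norvegicus, strain Sprague-Dawley), read by LC-MS (on this read-out lower numbers stand for a shorter-lived compound and higher numbers for a longer-lived compound), compound 1 (`N#Cc1ccc(O[C@H]2CN(S(=O)(=O)c3ccc(Cl)cc3Cl)C[C@@]2(O)CO)cc1`) gives 0.6 h and compound 2 (`N#Cc1ccc(S(=O)(=O)[C@H]2CN(S(=O)(=O)c3ccc(Cl)cc3Cl)C[C@@]2(O)CO)cc1`) gives 1.7 h as the higher of the two numbers, with a gap between them that lies beyond the usual scatter. With only these two numbers in hand, no trend can be drawn from the series.

Compound 3 (`N#Cc1ccc(S(=O)(=O)[C@H]2CN(S(=O)(=O)c3ccc(Cl)cc3Cl)C[C@@]2(O)CO)cc1F`) awaits measurement. It differs from compound 2 by fluoro in place of hydrogen on an aromatic carbon, ortho to a cyano group and meta to a large group (fluoro in place of hydrogen on an aromatic carbon), which turns 4-cyanophenyl into 4-cyano-3-fluorophenyl. Going by the values given here, no measured pair of compounds shows such a change, so the data offer no direct guide to its size in this assay or to its direction. The expectation therefore starts from compound 2 at 1.7 h and assumes no step beyond the scatter. The estimated step of a 1.1-fold higher number from compound 2 to compound 3 (0.02 log units; within the scatter) is expected to stay within that scatter, with no firm direction. For compound 3 the expected value is 1.8 h with an estimated range from 0.9 h to 3.5 h in the coming measurement.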

Compound 3, mean residence time: 0.8 h
For compound 3 the middle estimate is 2.3-fold (0.35 log units) above the measured one, outside the stated range (below it).
By their numbers in this assay, from the lowest: compounds 1 and 3 (each within the scatter of the next); then compound 2.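

Fluoro in place of hydrogen on an aromatic carbon, ortho to a cyano group and meta to a large group, is the first single change that can be read in this assay, and it gives a 2.1-fold lower number from compound 2 to compound 3 (0.33 log units; beyond the scatter) as a modest step. This shows that the position is not indifferent to substitution: one added fluorine atom, turning 4-cyanophenyl into 4-cyano-3-fluorophenyl, is enough to shift the mean residence time of compound 2 downward by more than the usual scatter. The data shown give no explanation for this step, which rests on a single pair of compounds.

From the compounds shown here alone, it remains open whether the step is specific to fluoro or would also appear with another group at this position, such as chloro, methyl or methoxy. Going by these compounds, it is also open whether fluoro on another aromatic carbon of the 4-cyanophenyl group would give a similar step, and whether the same change made on compound 1 would move the read-out in the same direction.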